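Cytotoxicity notes: trimethoxyphenyl variant of compound 2

A few compounds are considered here, and "the series" means these few. Any claim that something is new, unique, unknown or untested is made for them only; others in the source may bear on it.

compound 1 `O=c1cc(-c2ccccc2OCc2ccccc2)oc2cc(OCCCCCCCCN3CCCC3)ccc12`: 19.7%
compound 2 `O=c1cc(-c2ccccc2O)oc2cc(OCCCCCCCCN3CCCC3)ccc12`: 5.92%

In an ADME assay on HepG2 cells (Homo sapiens) for cytotoxicity, read by MTT assay, with a stated time of 48 h, tested at 1 uM (a lower number here means a weaker effect, a higher number a stronger effect of the compound at the concentration tested), compound 1 gives 19.7% and compound 2 gives 5.92%, the lowest of the two numbers. Among the compounds with values here, the only measured step is a number 13.8 percentage points lower from compound 1 to compound 2 (beyond the scatter), a modest drop when benzyl was removed. Compound 3 `COc1cc(-c2cc(=O)c3ccc(OCCCCCCCCN4CCCC4)cc3o2)cc(OC)c1OC` differs from compound 2 by 3,4,5-trimethoxyphenyl in place of 2-hydroxyphenyl on an aromatic carbon. Within the data shown here, no measured step exchanges the whole aryl group, so that benzyl step bears only loosely. A modest rise is nonetheless expected, a number 8.1 percentage points higher from compound 2 to compound 3 (within the scatter). Compound 3 is estimated at 14%, with a range from 2% to 30%.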

Compound 3, a percentage reported as inhibition, at one concentration (the size of the read-out at that concentration, not a potency): 16.3%
For compound 3 the middle estimate is 2.3 percentage points below the measured one; low and high end bracket the measured number.
By their numbers in this assay, from the lowest: compound 2; then compounds 3 and 1 (each within the scatter of the next).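

On the aromatic carbon next to the ring oxygen, exchanging the whole aryl group changes the read-out in this assay: the step is a number 10.4 percentage points higher from compound 2 to compound 3 (beyond the scatter) on putting 3,4,5-trimethoxyphenyl in place of 2-hydroxyphenyl. The position therefore responds to a replacement of the aryl group itself, not only to removal of benzyl from the oxygen. Compound 2, with the free hydroxyl, now sits lowest of the compounds shown, with no compound going against this.

Open, on these data alone, is whether a plain phenyl group or a phenyl group bearing a single methoxy reads like compound 2 or like compound 3. No measurement here speaks to the reason for the rise.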